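The compounds below may be only part of what the source reports. "The series", "measured", "known", "first", "only" and "open" are said of these compounds alone.

Measured compounds:
compound 1 `CN1CCN(Cc2ccc(Nc3ncc(Cl)c(Nc4ccccc4S(=O)(=O)N4CCCC4)n3)cc2)CC1` — 2 nM
compound 2 `CN1CCN(Cc2ccc(Nc3ncc(Cl)c(Nc4ccc(F)cc4S(=O)(=O)N4CCOCC4)n3)cc2)CC1` — "not determined" (no result reported)

This account follows the step from compound 2 to compound 3. In a functional assay on PSN1 cells (Homo sapiens) for cytotoxicity, read by luminescence, with a stated time of 96 h (on this read-out higher numbers stand for weaker inhibition and lower numbers for stronger inhibition), compound 1 gives 2 nM. For compound 2, with its (morpholin-4-yl)sulfonyl group, the result in this assay is "not determined" (no result reported), so no number stands against it and nothing can be said of where it lies relative to compound 1.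

Compound 3 `CN1CCN(Cc2ccc(Nc3ncc(Cl)c(Nc4ccc(F)cc4S(=O)(=O)N4CCCC4)n3)cc2)CC1` is not yet measured in this assay. It differs from compound 2 in one place: pyrrolidin-1-yl in place of morpholin-4-yl on a sulfonyl sulfur. Among the compounds with values here, the pyrrolidin-1-yl on the sulfonyl sulfur is the same group that compound 1 carries, so compound 1 is the nearest measured point of reference for compound 3, although the two are not a single-change pair and no step between them is given. Since compound 2 has no number, no size or direction of the step in this assay can be computed; the expectation for compound 3 therefore rests on compound 1 alone. Compound 3 is expected to give about 3 nM in this assay, with a range from 1 nM to 15 nM.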

Compound 3, half-maximal inhibitory concentration: 9 nM
Compound 3: the middle estimate sits 3.0-fold (0.48 log units) below what was measured, within the range that was stated.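

The swap of morpholin-4-yl for pyrrolidin-1-yl on a sulfonyl sulfur cannot be read in this assay: compound 2 has no result there, so compound 3 gives this change neither a size nor a direction. Within the data shown here, what compound 3 does add is the first reading on the fluoro group, since with the (pyrrolidin-1-yl)sulfonyl group held constant, fluoro in place of hydrogen on an aromatic carbon gives a 4.5-fold higher number from compound 1 to compound 3 (0.65 log units; beyond the scatter), a modest weakening that lies beyond the usual scatter. No measurement among the data shown accounts for this loss.

As far as these compounds go, whether the fluoro group costs the same with morpholin-4-yl on the sulfonyl sulfur remains open, and so does any ranking of the two rings, as both questions would need a number for compound 2. The compounds shown also leave open how an open-chain dimethylamino group or a piperidin-1-yl ring on the sulfonyl sulfur would read in this assay, and whether a chloro or a methoxy group on that aromatic carbon would follow the fluoro group.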